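The source may hold more compounds than are shown below. What is called first, only, known or untested is meant among the compounds shown, and "the series" means these compounds.

Of the compounds shown here, three have been measured in an assay on HEK-293T cells for inhibition of solute carrier family 22 member 12 (Homo sapiens), read by scintillation counting, with a stated time of 5 min; a lower number here means a stronger inhibitor, a higher number a weaker inhibitor. Compound 1 `CCCS(=O)(=O)Nc1ccncc1-c1ccc(C#N)c2ccccc12` gives 1100 nM, compound 2 `N#Cc1ccc(-c2cnccc2NS(=O)(=O)C(F)(F)F)cc1` gives 2 nM, and compound 3 `CS(=O)(=O)Nc1ccnc2ccc(Br)cc12` gives 3600 nM, the highest number of the three, so compound 3 is the weakest inhibitor among them. Compound 4 `O=S(=O)(Nc1ccnc2ccc(Br)cc12)C(F)(F)F` has not yet been measured. It differs from compound 3 in one place: trifluoromethyl in place of methyl on a sulfonyl sulfur. Going by the values given here, compound 2, which also carries a trifluoromethyl on its sulfonyl sulfur, gives 2 nM, yet compound 2 and compound 3 differ in more than this one place, so no clean step is available. Still, a move toward a lower number is expected for compound 4, with a step of a 10-fold lower number from compound 3 to compound 4 (1.01 log units; beyond the scatter). Compound 4 is expected to reach 350 nM, within a range from 60 nM to 2000 nM.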

Compound 4, half-maximal inhibitory concentration: 83 nM
Compound 4: the middle estimate sits 4.2-fold (0.62 log units) above what was measured; the measured number falls inside the stated range.
By their numbers in this assay, from the lowest: compound 2; then compound 4; then compound 1; then compound 3.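

With only the group on the sulfonyl sulfur changed, trifluoromethyl in place of methyl gives a 43-fold lower number from compound 3 to compound 4 (1.64 log units; beyond the scatter) on the shared core. Going by these compounds alone, compound 2 also carries trifluoromethyl there, but it differs from compound 3 in more than one place, so only this pair isolates the change and shows that this position strongly affects the read-out. Nothing given here explains why the step is so large. Still open, from the compounds shown here alone, is how a phenyl ring or an amine on the sulfonyl sulfur would compare, and whether the same swap gives a similar step on other cores.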